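The source may report more compounds than this note shows. Statements on the series, on what has been measured and on what is new or still open speak of the compounds shown alone.

Measured so far:
compound 1, `CCCCNC(=O)N1CC1C#N`: 15000 nM
compound 2, `N#CC1CN1C(=O)Nc1ccc(F)cc1`: 3400 nM

In a functional assay on A-375 cells (Homo sapiens) for inhibition (a lower number here means a stronger inhibitor, a higher number a weaker inhibitor), compound 1 gives 15000 nM, the higher of the two numbers in hand. The nearest point of comparison is compound 2, which in this assay gives 3400 nM; the gap between compound 1 and compound 2 lies beyond the scatter, so compound 1 reads as the weaker inhibitor of the pair. Compound 2 differs from compound 1 in more than one place, so its value shows only where the series has reached, not what a single change does.

Compound 3, `CCNC(=O)N1CC1C#N`, has not yet been measured. Relative to compound 1 the change is hydrogen in place of ethyl on a saturated chain carbon, two bonds along the chain from an amide-type nitrogen. Among the measured compounds shown here, no measured pair in the set isolates this change, so there is no step to lean on. The expectation is a small step from compound 1 to compound 3, a 1.3-fold higher number from compound 1 to compound 3 (0.12 log units; within the scatter), toward a weaker inhibitor, with no change beyond the scatter also plausible. Compound 3 is thus estimated at 20000 nM, with a range from 8000 nM to 60000 nM.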

Compound 3, half-maximal inhibitory concentration: 36000 nM
The estimate for compound 3 lay 1.8-fold (0.26 log units) below the measured number; the range from low to high includes it.
By their numbers in this assay, from the lowest: compound 2; then compound 1; then compound 3.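

Replacing the ethyl at this place, which turns the butyl chain into an ethyl chain, gives a 2.4-fold higher number from compound 1 to compound 3 (0.38 log units; beyond the scatter) in this assay. Among the compounds shown here, this is the first single-place change, and it shows that this chain position is not neutral: the shorter chain moves toward a weaker inhibitor, though the step is modest. With the shared core unchanged, the number responds to the outer part of the chain alone. Nothing measured here bears on why the number rises.

A single step cannot show whether this response continues with a longer chain such as hexyl or reverses. It also leaves open whether a branched chain such as isobutyl or a ring such as cyclohexyl at this place would match the butyl chain.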